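Dichlorophenyl urea compared with its chloro-trifluoromethyl analogue

The compounds below may be only part of what the source reports. "The series", "measured", "known", "first", "only" and "open" are said of these compounds alone.

Measured compounds:
compound 1, `COc1cc2cc(Oc3ccc(NC(=O)Nc4cccc(C(F)(F)F)c4)cc3)c(C)nc2cc1OC`, gives 1710 nM in a functional assay on NCI/ADR-RES cells (Homo sapiens) for inhibition, read by sulforhodamine B assay, with a stated time of 48 h; on this read-out higher numbers stand for weaker inhibition of growth and lower numbers for stronger inhibition of growth;
compound 2, `COc1cc2cc(Oc3ccc(NC(=O)Nc4ccc(Cl)c(C(F)(F)F)c4)cc3)c(C)nc2cc1OC`, gives 1060 nM in this assay.

Among the measured compounds shown here, compound 2 stands at the lowest of the two numbers, and its nearest neighbour is compound 1; the only measured step, a 1.6-fold lower number from compound 1 to compound 2 (0.21 log units; within the scatter), is within the scatter, so the two compounds cannot be separated on these data.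

Compound 3, `COc1cc2cc(Oc3ccc(NC(=O)Nc4ccc(Cl)c(Cl)c4)cc3)c(C)nc2cc1OC`, is not yet measured. It differs from compound 2 by chloro in place of trifluoromethyl on an aromatic carbon. For the measured compounds named here, no measured pair exchanges a trifluoromethyl group for a chloro group, so nothing here shows how that change reads. Going by the values given here, the one measured step, a 1.6-fold lower number from compound 1 to compound 2 (0.21 log units; within the scatter), concerns a different site and is itself within the scatter. On that basis no change beyond the scatter is expected in this assay for compound 3, and the step of a 1.2-fold higher number from compound 2 to compound 3 (0.09 log units; within the scatter) is an estimate only. Compound 3 is therefore expected to give about 1300 nM in this assay, with a range from 500 nM to 3500 nM.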

Compound 3, concentration for 50% growth inhibition: 2600 nM
Beside the measured number, compound 3's estimate is 2.0-fold (0.30 log units) below it; measured number inside the range.
By their numbers in this assay, from the lowest: compounds 2, 1 and 3 (each within the scatter of the next, the first and the last beyond it).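

In this assay, among the compounds shown here, the exchange of trifluoromethyl for chloro at this position, on the aromatic carbon ortho to a chloro group, gives a 2.5-fold higher number from compound 2 to compound 3 (0.39 log units; beyond the scatter); this modest change is the first step to lie beyond the scatter, so this position does register a change of group. That effect shows only in this one pair, however: the other new comparison, 3,4-dichlorophenyl in place of 3-(trifluoromethyl)phenyl on the amide-type nitrogen, gives a 1.5-fold higher number from compound 1 to compound 3 (0.18 log units; within the scatter), which is within the scatter and leaves those two compounds inseparable. No measurement is available that could account for the difference between trifluoromethyl and chloro here.

The compounds shown leave open how other groups at this position, such as a nitrile, a methyl or a methoxy group, would read relative to trifluoromethyl and chloro. They also leave open whether the exchange of trifluoromethyl for chloro would give a step of similar size if the neighbouring chloro group were replaced by a fluoro group or by a morpholine ring.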